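The source may hold more compounds than are shown below. What is called first, only, known or untested is meant among the compounds shown, and "the series" means these compounds.

Measured so far in a functional assay on Hep 3B2 cells (Homo sapiens) for antiproliferative activity, read by MTT assay, with a stated time of 24 h, tested at 33.33 ug/mL; a higher number here means a stronger effect of the compound at the concentration tested, a lower number a weaker effect:

compound 1 `CCc1ccc2nc(C(=O)Nc3c(F)cc(-c4cccc(F)c4)cc3F)c(C)c(O)c2c1`: 56.3%
compound 2 `CCc1ccc2nc(C(=O)Nc3c(F)cc(-c4cccc(F)c4)cc3F)c(C)c(C(=O)O)c2c1`: 36.3%

Within the data shown here, compound 2 stands lowest of the two numbers in this assay, with compound 1 as its only neighbour; the single measured step, a number 20 percentage points lower from compound 1 to compound 2 (beyond the scatter), separates the two and lies beyond the scatter.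

Compound 3 `Cc1c(C(=O)Nc2c(F)cc(-c3cccc(F)c3)cc2F)nc2ccc(C(F)(F)F)cc2c1C(=O)O` differs from compound 2 by trifluoromethyl in place of ethyl on an aromatic carbon. Among the measured compounds shown here, no measured step bears on this change: the one step in hand, a number 20 percentage points lower from compound 1 to compound 2 (beyond the scatter), concerns carboxy in place of hydroxy, a feature compound 3 shares with compound 2. With nothing measured on the ethyl position, no direction can be read off, and the default is a step within the scatter from the number for compound 2. For compound 3 the number in this assay is estimated at 38%, with a range of 18% to 58%. The expected step is a number 1.7 percentage points higher from compound 2 to compound 3 (within the scatter), not beyond the scatter.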

Compound 3, a percentage reported as inhibition, at one concentration (the size of the read-out at that concentration, not a potency): 43.3%
The estimate for compound 3 lay 5.3 percentage points below the measured number; measured number inside the range.
By their numbers in this assay, from the lowest: compounds 2 and 3 (each within the scatter of the next); then compound 1.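

In this assay, among these compounds, trifluoromethyl in place of ethyl on an aromatic carbon gives a number 7 percentage points higher from compound 2 to compound 3 (within the scatter) and is the first measured change at this position, as the earlier step concerned only carboxy in place of hydroxy. With the carboxy group held constant, this exchange of ethyl for trifluoromethyl does not separate compound 2 and compound 3 in this assay, so neither group stands out here at the single concentration tested. No measured evidence bears on why these two groups read alike.

As far as these compounds go, whether the same exchange would read alike with hydroxy in place of carboxy stays open. Also open, from the compounds shown here alone, is how an amine, a methoxy group, a chlorine atom or a longer chain at this position would compare with ethyl and trifluoromethyl.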